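The source may hold more compounds than are shown below. What is called first, only, known or untested is meant among the compounds shown, and "the series" means these compounds.

Three compounds with a shared arrangement of a bicyclic amine, a six-membered nitrogen-containing ring and an aniline have been measured in an assay on cell membranes for displacement of a labelled ligand from Neuronal acetylcholine receptor; alpha4/beta2 (Rattus norvegicus); on this read-out higher numbers stand for weaker inhibition and lower numbers for stronger inhibition. Compound 1 `Fc1ccc(Nc2ccc(N3CC4CC(C3)N4)nn2)cc1` carries a fluoro on the aniline ring and gives 868 nM. Compound 2 `COc1ccc(Nc2ccc(N3CC4CC(C3)N4)nn2)cc1` differs from it only in the change (methoxy in place of fluoro on an aromatic carbon), and compound 2 gives 578 nM. That single change produced a 1.5-fold lower number from compound 1 to compound 2 (0.18 log units; within the scatter), so on this evidence swapping fluoro for methoxy leaves the result essentially unchanged.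

Compound 3 `Fc1ccc(Nc2ccc(N3CC4CC(C3)N4)cn2)cc1` keeps the fluoro aniline but has a different core from compound 1; the difference between the two cores is not broken down here. In this assay compound 3 gives 2.38 nM, a far lower number than either compound 1 or compound 2, so compound 3 is the strongest binder of the three measured.

Compound 4 `COc1ccc(Nc2ccc(N3CC4CC(C3)N4)cn2)cc1` has not yet been measured. It stands to compound 3 exactly as compound 2 stands to compound 1: the change is methoxy in place of fluoro on an aromatic carbon, and the two places are described in the same words, so it is the same change made on the core of compound 3 instead of the core of compound 1. Because compound 1 to compound 2 showed a 1.5-fold lower number from compound 1 to compound 2 (0.18 log units; within the scatter), the step from compound 3 to compound 4 in this assay is expected to be a 1.2-fold lower number from compound 3 to compound 4 (0.08 log units; within the scatter), a step within the scatter. Compound 4 is therefore estimated to give 2 nM, with a likely range from 0.8 nM to 5 nM.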

Compound 4, inhibition constant: 7.3 nM
Estimate against measurement, compound 4: 3.7-fold (0.56 log units) below, outside the stated range (above it).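

In this assay, methoxy in place of fluoro gives a 3.1-fold higher number from compound 3 to compound 4 (0.49 log units; beyond the scatter), so on the core of compound 3 the change modestly weakens binding, whereas on the core of compound 1 it left the result within the scatter. The same swap therefore does not carry over unchanged from one core to the other: the same change on two cores in this assay, a 1.5-fold lower number (0.18 log units; within the scatter) from compound 1 to compound 2 and a 3.1-fold higher number (0.49 log units; beyond the scatter) from compound 3 to compound 4, 4.6-fold (0.66 log units) apart, beyond the scatter of two such steps. This shows that the outcome of the swap depends on the core that carries it, but it rests on just two pairs of compounds and does not show which feature of the cores matters or why the two steps part ways, so a step seen on one core is a weak guide to the step on another in this series.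

The compounds shown have only fluoro or methoxy on the aniline ring, so it remains open how a different group at that place, such as an amine, a nitrile or a longer chain like ethoxy, would behave on either core. Going by these compounds, it also remains open whether such groups would show the same gap between the two cores or whether that gap is particular to the swap of fluoro for methoxy.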